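The source may hold more compounds than are shown below. What is called first, only, known or untested is meant among the compounds shown, and "the series" means these compounds.

Within the data shown here, compound 2 `CC1C(=O)N(O)C(=O)c2ccccc21` gives the highest of the three numbers measured so far in an ADME assay on MT4 cells (Homo sapiens) for cytotoxicity, read by MTT assay (on this read-out lower numbers stand for higher toxicity in this test and higher numbers for lower toxicity in this test), at 250000 nM. Compound 1 `O=C1c2ccccc2C(CCc2ccccc2)C(=O)N1O` gives 30000 nM in this assay, and compound 3 `O=C1c2ccccc2C(Cc2ccc(C(F)(F)F)cc2)C(=O)N1O` gives 6000 nM in this assay, so both sit well apart from compound 2 and beyond the scatter.

The next compound is compound 4 `CCCCC1C(=O)N(O)C(=O)c2ccccc21`. It differs from compound 2 by one change: propyl in place of hydrogen on a saturated chain carbon bound to a saturated ring carbon.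

Among the measured compounds shown here, only one measured step bears on a change at this place. There, an 8.3-fold higher number from compound 1 to compound 2 (0.92 log units; beyond the scatter), so removing a larger chain with a ring at this position raised the number. For the measured compounds named here, compound 4 adds a chain of the counted size without a ring at the same place, a smaller addition than the one removed between compound 1 and compound 2. The number for compound 4 is therefore expected to fall again, by less than that step, so that in this assay compound 4 is expected to give about 80000 nM, plausibly between 25000 nM and 250000 nM, that is a 3.1-fold lower number from compound 2 to compound 4 (0.49 log units; beyond the scatter).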

Compound 4, half-maximal cytotoxic concentration: 25400 nM
The estimate for compound 4 lay 3.1-fold (0.50 log units) above the measured number, and the stated range covers the measured number.
By their numbers in this assay, from the lowest: compound 3; then compounds 4 and 1 (each within the scatter of the next); then compound 2.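

In this assay putting propyl in place of hydrogen on a saturated chain carbon bound to a saturated ring carbon gives a 9.8-fold lower number from compound 2 to compound 4 (0.99 log units; beyond the scatter) and so shows that a chain without a ring is enough to bring the number down. Ethyl in place of phenyl on a saturated chain carbon, two bonds along the chain from a saturated ring carbon, gives a 1.2-fold lower number from compound 1 to compound 4 (0.07 log units; within the scatter) and so, for this pair, having a phenyl at the end of the chain makes no difference that can be told from the scatter. Nothing measured here explains this drop.

On these data alone, it remains open whether a chain shorter than butyl already gives the same drop, and whether a longer chain lowers the number further. Also open, as far as these compounds go, is how an amine or a carboxylic acid at the end of the chain would change the number.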